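Aryl ether series: carbamoyl to acetamido step

The source may hold more compounds than are shown below. What is called first, only, known or untested is meant among the compounds shown, and "the series" means these compounds.

Measured compounds:
compound 1 `COc1cc(C#N)ccc1OCCCN1CCC(C(c2ccc(F)cc2)c2ccc(F)cc2)CC1`: 2 nM
compound 2 `NC(=O)c1ccc(OCCCN2CCC(C(c3ccc(F)cc3)c3ccc(F)cc3)CC2)cc1`: 31.6 nM

For the measured compounds named here, in a functional assay (aorta) with Oryctolagus cuniculus as the target (a higher number here means weaker binding, a lower number tighter binding), compound 2 gives 31.6 nM, the highest of the two numbers; the only measured step, a 16-fold higher number from compound 1 to compound 2 (1.20 log units; beyond the scatter), changes the same aryl group and shows that substitution there can move the number a long way. Compound 3 `CC(=O)Nc1ccc(OCCCN2CCC(C(c3ccc(F)cc3)c3ccc(F)cc3)CC2)cc1` differs from compound 2 by acetamido in place of carbamoyl on an aromatic carbon. Going by the values given here, no measured step covers this exchange, so the expectation for compound 3 is a step of a 1.0-fold higher number from compound 2 to compound 3 (0.01 log units; within the scatter), not beyond the scatter. For compound 3 the estimate is 32 nM, expected between 10 nM and 100 nM.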

Compound 3, dissociation constant: 12.6 nM
For compound 3 the middle estimate is 2.5-fold (0.40 log units) above the measured one; the range from low to high includes it.
By their numbers in this assay, from the lowest: compound 1; then compound 3; then compound 2.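

Acetamido in place of carbamoyl is the first exchange read at this aromatic carbon with the rest of the 4-substituted phenyl group held, and in this assay it gives a 2.5-fold lower number from compound 2 to compound 3 (0.40 log units; beyond the scatter). The 4-cyano-2-methoxyphenyl group still keeps the lowest number, with a 6.3-fold higher number from compound 1 to compound 3 (0.80 log units; beyond the scatter), so acetamido closes only part of the gap to compound 1. No supporting data bear on this step.

Open, from the compounds shown here alone, is how a carboxylic acid, an amine or a longer acyl chain at this carbon would read. Also open, going by these compounds, is how much of the gap to compound 1 belongs to the nitrile and how much to the methoxy group.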